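The compounds below may be only part of what the source reports. "The series", "measured", "known", "first", "only" and "open" are said of these compounds alone.

Measured compounds in a physicochemical assay for lipophilicity, read by HPLC; on this read-out higher numbers stand for higher lipophilicity and lower numbers for lower lipophilicity:
compound 1 `Cc1cccc(NC(=O)c2ccc3cccc(O)c3n2)c1` — 2.5
compound 2 `O=C(Nc1ccccc1Cl)c1ccc2cccc(O)c2n1` — 2.5

In this assay compound 1 gives 2.5 and compound 2 gives 2.5; the step of no change at the digits printed from compound 1 to compound 2 (within the scatter) lies within the scatter, so compound 1 stands level with compound 2, its nearest neighbour in this assay.

Compound 3 `O=C(Nc1cccc(C(F)(F)F)c1)c1ccc2cccc(O)c2n1` is not yet measured. It differs from compound 1 by trifluoromethyl in place of methyl on an aromatic carbon, meta to a large group. Among the measured compounds shown here, no measured step covers this exchange: the single measured step, no change at the digits printed from compound 1 to compound 2 (within the scatter), concerns a different swap of the aryl group and is itself within the scatter, so it offers no direct guide to size or direction. The step of a number 0.40 log units higher from compound 1 to compound 3 (beyond the scatter) is therefore an estimate only, expected to be a small rise of about the size of the scatter. For compound 3 the expected value in this assay is 2.9, with a range from 2.5 to 3.3.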

Compound 3, partition coefficient: 2.5
For compound 3 the middle estimate is 0.40 log units above the measured one; the measured number falls inside the stated range.
By their numbers in this assay, from the lowest: compounds 1, 2 and 3 (each within the scatter of the next).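

Trifluoromethyl in place of methyl on an aromatic carbon, meta to a large group, reads in this assay as no change at the digits printed from compound 1 to compound 3 (within the scatter) and thus gives a level result for a single group exchange at one place on the aryl ring. The earlier step replaced 3-methylphenyl with 2-chlorophenyl, whereas here the position stays fixed and a group of 4 heavy atoms replaces one of 1 heavy atom without a step beyond the scatter. No measurement at hand accounts for this level reading.

As far as these compounds go, whether the reading stays level at this place with an amine, a carboxylic acid or a longer chain remains open. From the compounds shown here alone, all three compounds also share the core of compound 1, so the effect of changes to that core on this read-out is unknown.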